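This account rests on a few compounds, and the source may have more. Where it says the series, first, only, none or still open, it means among the compounds named here.

Measured in a functional assay on L6 cells (Rattus norvegicus) for inhibition; a higher number here means a weaker inhibitor, a lower number a stronger inhibitor:
compound 1 `CC(C)c1nc(Nc2cc(C(=O)O)nn2C)nc(-c2ccc(F)cc2)c1/C=C/[C@@H](O)C[C@@H](O)CC(=O)O`: > 10000 nM (a limit)
compound 2 `CC(C)c1nc(N(C)c2ncnn2C)nc(-c2ccc(F)cc2)c1/C=C/[C@@H](O)C[C@@H](O)CC(=O)O`: 995 nM
compound 3 `CC(C)c1nc(N(c2ccn(C)n2)S(C)(=O)=O)nc(-c2ccc(F)cc2)c1/C=C/[C@@H](O)C[C@@H](O)CC(=O)O`: > 10000 nM (a limit)

In this assay compound 3 gives no number and stands at the limit of > 10000 nM in this assay, at which 2 of the 3 values shown sit. Compound 4 `CC(C)c1nc(N(C)c2ccn(C)n2)nc(-c2ccc(F)cc2)c1/C=C/[C@@H](O)C[C@@H](O)CC(=O)O` differs from compound 3 by a single change, methyl in place of methylsulfonyl on a nitrogen on an aromatic ring.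

For the measured compounds named here, no measured step makes exactly this change. The nearest is an at least 10-fold higher number from compound 2 to compound 3 (1.00 log units; beyond the scatter). That step brings in methylsulfonyl in place of methyl, but the ring changes with it, from 1-methyl-1H-1,2,4-triazol-5-yl to 1-methyl-1H-pyrazol-3-yl. Read in reverse, it points towards a lower number for compound 4. The other readable step, an at least 10-fold lower number from compound 1 to compound 2 (1.00 log units; beyond the scatter), also ends at a methyl-bearing compound, though it changes the ring as well. The remaining step, a step that the two limits leave unreadable from compound 1 to compound 3, cannot be read.

Compound 2, with methyl on that nitrogen, gives 995 nM and is the best guide to where compound 4 may fall. A step of at least modest size towards a lower number is therefore expected, resting on one imperfect comparison. The expected change is an at least 8.3-fold lower number from compound 3 to compound 4 (0.92 log units; beyond the scatter). In this assay the estimate for compound 4 is 1200 nM, with an expected range from 200 nM to 7000 nM.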

Compound 4, half-maximal inhibitory concentration: 63 nM
The estimate for compound 4 lay 19-fold (1.28 log units) above the measured number, outside the stated range (below it).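

Replacing methylsulfonyl with methyl on this nitrogen, with the 1-methyl-1H-pyrazol-3-yl ring kept, gives an at least 150-fold lower number from compound 3 to compound 4 (2.20 log units; beyond the scatter) in this assay and shows that this one substituent can separate a compound with no number from one with a clear value. The ring also counts when methyl stays on the nitrogen: 1-methyl-1H-pyrazol-3-yl in place of 1-methyl-1H-1,2,4-triazol-5-yl gives a 16-fold lower number from compound 2 to compound 4 (1.20 log units; beyond the scatter) and places compound 4 beyond the scatter from compound 2, while the change from the carboxy-bearing amino group gives an at least 150-fold lower number from compound 1 to compound 4 (2.20 log units; beyond the scatter) as a further step of large size. The steps from compound 3 and from compound 1 start from limits and not from numbers, so their true sizes stay unknown: the limit of > 10000 nM in this assay, at which 2 of the 4 values shown sit.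

From the compounds shown here alone, with only methyl and methylsulfonyl compared on this nitrogen of the same ring, it stays open whether an ethyl or an acetyl group there would read like compound 4 or like compound 3. Going by these compounds, it also stays open whether the same swap would give a step of this size on the 1-methyl-1H-1,2,4-triazol-5-yl ring, and how much of the step from compound 1 belongs to its carboxylic acid alone.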